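A few compounds are considered here, and "the series" means these few. Any claim that something is new, unique, unknown or untested is made for them only; others in the source may bear on it.

In a functional assay on HepG2 cells (Homo sapiens) for antiproliferative activity, read by MTT assay, with a stated time of 48 h (a higher number here means a weaker inhibitor, a lower number a stronger inhibitor), compound 1 `N#CC1=C(N)Oc2c(c3nc4ccccc4nc3c3ccccc23)C12C(=O)N(Cc1cnnn1-c1ccc(S(N)(=O)=O)cc1)c1ccccc12` gives 42200 nM. Compound 2 `N#CC1=C(N)Oc2c(N)cc3nc4ccccc4nc3c2C12C(=O)N(Cc1cnnn1-c1ccc(F)cc1)c1ccccc12` returns only a limit of the assay in this assay, namely > 50000 nM. On the numbers shown, compound 2 therefore sits at the limit of > 50000 nM in this assay, at which 1 of the 2 values shown sits, with no measured number of its own. Compound 3 `N#CC1=C(N)Oc2c(N)cc3nc4ccccc4nc3c2C12C(=O)N(Cc1cnnn1-c1ccc([N+](=O)[O-])cc1)c1ccccc12` differs from compound 2 by nitro in place of fluoro on an aromatic carbon. Among the measured compounds shown here, no step between measured compounds covers this change, so its effect is unknown from the data. The step from compound 2 to compound 3 is expected to be a number no higher from compound 2 to compound 3 (the limit leaves the size open), that is, nothing beyond the usual scatter. Compound 3 is expected to give about 50000 nM in this assay, within 15000 nM to 160000 nM, most likely again reported only as a limit.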

Compound 3, half-maximal inhibitory concentration: > 50000 nM
Compound 3: no number, only a limit; the forecaster's own chance of this, stated with the estimate: 60%; the middle value sits exactly at the limit.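

Compound 3 gives only a limit of the assay, > 50000 nM, and compound 2 also gives only a limit, so no step can be read between them. Going by these compounds, what nitro in place of fluoro does to the activity stays open.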